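The compounds below may be only part of what the source reports. "The series", "measured", "known", "first", "only" and "open" are said of these compounds alone.

Compound 1, `O=C1NC(=O)C(c2ccccc2)CC1c1ccccc1`: 70.2%
Compound 2, `O=C1NC(=O)C(c2ccccc2Cl)CC1c1ccccc1Cl`: 58.3%

Of the compounds shown here, two sharing one core have been tested in a functional assay on the whole organism (strain Swiss albino) for inhibition, with Mus musculus as the target, in the maximal electroshock model, with a stated time of 2 h, at a dose of 25 mg/kg by the intraperitoneal route; on this read-out lower numbers stand for less inhibition and higher numbers for more inhibition at the one dose given (going by the name of the read-out). Compound 1 gives 70.2%. Compound 2, carrying a chlorine on each of its two phenyl rings, gives 58.3%, which is the lower of the two numbers; the gap to compound 1 lies beyond the usual scatter of this kind of measurement, so compound 2 stands clearly below compound 1 in this assay.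

The next compound to be tested is compound 3, `O=C1C(c2ccccc2Cl)CC(c2ccccc2Cl)C(=O)N1c1ccccc1`. Relative to compound 2 the change is phenyl in place of hydrogen on an amide-type nitrogen in a ring. The two 2-chlorophenyl groups on the ring are kept; only the amide hydrogen is replaced by the phenyl group. Within the data shown here, no pair of measured compounds shows this change, so its effect in this assay cannot be read from the data at hand.

Given that, a step of modest size is expected, leaning downward but not clearly beyond the scatter: compound 3 is estimated to give 50%, with a range from 25% to 75%, which means an expected step of a number 8.3 percentage points lower from compound 2 to compound 3 (within the scatter).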

Compound 3, a percentage reported as inhibition, in the whole organism at one dose (the size of the read-out at that dose, not a potency): 40.6%
Beside the measured number, compound 3's estimate is 9.4 percentage points above it; the measured number falls inside the stated range.
By their numbers in this assay, from the lowest: compound 3; then compound 2; then compound 1.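

Until this point the data held no change on the amide-type nitrogen. Replacing the amide hydrogen with phenyl while keeping both 2-chlorophenyl groups gives, in this assay, a number 17.7 percentage points lower from compound 2 to compound 3 (beyond the scatter), a modest step, which shows that this position is not indifferent to substitution on the chlorinated compounds. The step does not remove the effect, since compound 3 still gives 40.6% at the one dose tested, so a hydrogen on this nitrogen is not needed for a measurable read-out, and nothing shown here accounts for why the number moves as it does.

From the compounds shown here alone, whether the step belongs to phenyl in particular, or would come with any group on this nitrogen, stays open, and a methyl group, a benzyl group or a longer alkyl chain at the same place would speak to that. Also open, going by these compounds, is whether the same replacement would take a similar step on compound 1, which has no chlorine on its phenyl rings, as this single pair rests on one dose, one time point and the chlorinated compounds alone.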